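Cyclopropyl to Phenethyl on a Weakly Inhibiting Core

The source may hold more compounds than are shown below. What is called first, only, known or untested is meant among the compounds shown, and "the series" means these compounds.

Compound 1 `O=c1cc(Cn2cc(C3CC3)nn2)c2ccc(O)cc2o1` gives 91700 nM in a functional assay on A549 cells (Homo sapiens) for inhibition, read by MTT assay, with a stated time of 72 h (on this read-out lower numbers stand for stronger inhibition and higher numbers for weaker inhibition), and stands highest of the two numbers shown, with compound 2 `O=c1cc(Cn2cc(CCO)nn2)c2ccc(O)cc2o1` giving 90300 nM close beside it. Compound 3 `CC(O)c1cn(Cc2cc(=O)oc3cc(O)ccc23)nn1` returns > 100000 nM in this assay, which is a limit of the assay and not a number. The change to compound 4 `O=c1cc(Cn2cc(CCc3ccccc3)nn2)c2ccc(O)cc2o1` is phenethyl in place of cyclopropyl on an aromatic carbon. Two measured changes at the same carbon bear on it: a 1.0-fold lower number from compound 1 to compound 2 (0.01 log units; within the scatter) and an at least 1.0-fold higher number from compound 1 to compound 3 (0.03 log units; that floor lies within the scatter), both within the scatter, so exchanging the cyclopropyl there has so far shifted nothing. Compound 4 is therefore expected to stay close to compound 1. The expected step is a 1.0-fold lower number from compound 1 to compound 4 (0.01 log units; within the scatter). The estimate for compound 4 in this assay is 90000 nM, with a range from 40000 nM to 200000 nM.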

Compound 4, half-maximal inhibitory concentration: 24800 nM
Beside the measured number, compound 4's estimate is 3.6-fold (0.56 log units) above it; measured number outside the range, below it.
By their numbers in this assay, from the lowest: compound 4; then compounds 2 and 1 (each within the scatter of the next). At a limit, above all of these: compound 3.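

At this aromatic carbon the choice of group can change the number after all: in this assay, phenethyl gives a 3.7-fold lower number from compound 1 to compound 4 (0.57 log units; beyond the scatter), and exchanging the hydroxy of the chain for phenyl gives a 3.6-fold lower number from compound 2 to compound 4 (0.56 log units; beyond the scatter). Against compound 3 the step is an at least 4.0-fold lower number from compound 3 to compound 4 (0.60 log units; beyond the scatter). Compound 3 stands at a limit, which is not a number, so that step is only a floor: the limit of > 100000 nM in this assay, at which 1 of the 4 values shown sits.

Going by these compounds, it remains open whether the ring or the length of the chain matters more. A benzyl group, a directly attached phenyl or a longer chain ending in an amine could help separate the two.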